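Sulfanyl to benzylamino exchange on a weakly active diaminoquinoxaline pair

This account rests on a few compounds, and the source may have more. Where it says the series, first, only, none or still open, it means among the compounds named here.

Measured so far:
compound 1 `CCOC(=O)[C@H](CCC(=O)O)NC(=O)c1ccc(Sc2nc3cc(N)cc(N)c3nc2-c2ccccc2)cc1`: 63100 nM
compound 2 `Nc1cc(N)c2nc(-c3ccccc3)c(Sc3ccc(F)cc3)nc2c1`: < 100000 nM
compound 3 `CCOC(=O)[C@H](CCC(=O)O)NC(=O)c1ccc(CNc2nc3cc(N)cc(N)c3nc2-c2ccccc2)cc1`: 77600 nM

In a functional assay on SK-MEL-2 cells (Homo sapiens) for inhibition, read by sulforhodamine B assay, with a stated time of 48 h (on this read-out higher numbers stand for weaker inhibition of growth and lower numbers for stronger inhibition of growth), compound 1 gives 63100 nM and compound 3 gives 77600 nM, two values that sit within the usual scatter of each other. For compound 2 the result is a limit of the assay, < 100000 nM, at the limit of < 100000 nM in this assay, at which 1 of the 3 values shown sits, so compound 2 stands only at the weak end of the numbers shown without a value of its own. Compound 4 `Nc1cc(N)c2nc(-c3ccccc3)c(NCc3ccc(F)cc3)nc2c1` carries (4-fluorobenzyl)amino in place of (4-fluorophenyl)sulfanyl on an aromatic carbon. Among the compounds with values here, no measured step covers this change. Compound 4 is expected to stay weak, at an estimated 70000 nM with a range from 25000 nM to 100000 nM. This estimate means a step that the limit leaves unreadable from compound 2 to compound 4, expected to lie within the scatter rather than beyond it.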

Compound 4, concentration for total growth inhibition: < 100000 nM
Compound 4 was reported as a limit; the forecaster's own chance of this, stated with the estimate: 35%; the middle value is on the limit's open side.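

Compound 2 and compound 4 both give only a limit, so no step between them can be read in this assay: the limit of < 100000 nM in this assay, at which 2 of the 4 values shown sit.

The compounds shown leave open whether (4-fluorobenzyl)amino in place of (4-fluorophenyl)sulfanyl shifts growth inhibition at all in this pair.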